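The source may report more compounds than this note shows. Statements on the series, on what has been measured and on what is new or still open speak of the compounds shown alone.

Measured so far: compound 1 `CCOC(=O)c1cnc(-c2cc([N+](=O)[O-])ccc2OCC)[nH]c1=O`, which in a functional assay on the whole organism (strain Sprague-Dawley) for inhibition, with Rattus norvegicus as the target, with a stated time of 10 min (on this read-out higher numbers stand for an effect only at larger amounts of compound and lower numbers for an effect already at smaller amounts), gives 5 mg/kg; compound 2 `CCOC(=O)c1cnc(-c2cc(N(C)C)ccc2OCC)[nH]c1=O`, for which compound 2 has in this assay only the entry "not determined" (no result reported), no result having been reported.

Compound 2 thus has no number to stand on in this assay. Compound 3 `CCOC(=O)c1cnc(-c2cc(S(=O)(=O)N(CC)CC)ccc2OCC)[nH]c1=O` differs from compound 2 in one place: diethylsulfamoyl in place of dimethylamino on an aromatic carbon. For the measured compounds named here, no step between measured compounds is available, so the size of this step in this assay cannot be read from the data; the expectation is a change no larger than the usual scatter, in no firm direction. Going by the values given here, the only measured anchor is compound 1 at 5 mg/kg. Compound 3 is expected to give about 8 mg/kg, within 2 mg/kg to 30 mg/kg.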

Compound 3, dose for 50% inhibition: 10 mg/kg
Compound 3: the middle estimate sits 1.3-fold (0.10 log units) below what was measured, and the stated range covers the measured number.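

In this assay, the change from nitro to diethylsulfamoyl on this aromatic carbon gives a 2.0-fold higher number from compound 1 to compound 3 (0.30 log units; within the scatter), so two quite different groups at this position read alike. The step from compound 2 to compound 3 cannot be read, as compound 2 has no number. Nothing available explains why these two groups read alike.

Going by these compounds, whether dimethylamino fits this same range therefore stays open. So does the outcome with a carboxylic acid, a primary amine or an unsubstituted sulfonamide at this position.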